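A few compounds are considered here, and "the series" means these few. Any claim that something is new, unique, unknown or untested is made for them only; others in the source may bear on it.

Going by the values given here, in a functional assay on HeLa cells (Homo sapiens) for antiproliferative activity, read by MTT assay, with a stated time of 48 h (on this read-out lower numbers stand for stronger inhibition and higher numbers for weaker inhibition), compound 1 (`Fc1ccc2[nH]c(-c3cn(-c4ccccc4)nc3-c3ccccc3)nc2c1`) gives 3610 nM and compound 2 (`FC(F)(F)c1ccc2[nH]c(-c3cn(-c4ccccc4)nc3-c3ccccc3)nc2c1`) gives 1920 nM, so compound 2 stands within the usual scatter of its only measured neighbour. Compound 3 (`O=C(OCc1ccccc1)c1ccc2[nH]c(-c3cn(-c4ccccc4)nc3-c3ccccc3)nc2c1`) carries benzyloxycarbonyl in place of trifluoromethyl on an aromatic carbon. Among the compounds with values here, only one measured step bears on this change, a 1.9-fold lower number from compound 1 to compound 2 (0.27 log units; within the scatter), and it stayed small. Within the data shown here, no measured compound carries benzyloxycarbonyl, so the data point in no clear direction. The expected result in this assay is a 1.3-fold higher number from compound 2 to compound 3 (0.11 log units; within the scatter), with no shift beyond the scatter. For compound 3 the estimated value is 2500 nM, within an expected range from 800 nM to 8000 nM.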

Compound 3, half-maximal inhibitory concentration: 21300 nM
For compound 3 the middle estimate is 8.5-fold (0.93 log units) below the measured one; the measured number lies above the stated range.
By their numbers in this assay, from the lowest: compounds 2 and 1 (each within the scatter of the next); then compound 3.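

Benzyloxycarbonyl brings an 11-fold higher number from compound 2 to compound 3 (1.05 log units; beyond the scatter) and a 5.9-fold higher number from compound 1 to compound 3 (0.77 log units; beyond the scatter) in this assay so this position does respond to the group it carries, which the close values of compounds 1 and 2 did not show. Among the three groups shown, the one with the most heavy atoms and its own aromatic ring goes with the weakest inhibition. No measurement here gives a reason for this loss. From the compounds shown here alone, whether it follows the benzyl part or the carbonyl stays open; a carboxylic acid or a methyl ester at this position would help to separate the two.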